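This account rests on a few compounds, and the source may have more. Where it says the series, first, only, none or still open, it means among the compounds named here.

Of the compounds shown here, three from one series have been measured in a functional assay on the whole organism (strain CD1) for inhibition, with Mus musculus as the target, with stated times of 15 min and 20 min, at a dose of 10 mg/kg by the subcutaneous route; a lower number here means less inhibition, a higher number more inhibition at the dose given (going by the name of the read-out). Compound 1, `CCOC(=O)/C(C#N)=C/c1ccc(O)c(O)c1`, gives 57.8% in this assay. Compound 2, `CC(C)(C)OC(=O)/C(C#N)=C/c1ccc(O)c(O)c1`, gives 43.4% in this assay. Compound 3, `CCOC(=O)/C(C#N)=C/c1ccoc1`, gives 55.9% in this assay. The difference between the core of compound 1 and the core of compound 3 is not broken down here; their two values lie within the scatter of each other, so nothing is said about their order.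

For the measured compounds named here, the one structural change that has been measured is tert-butyl in place of ethyl on an oxygen next to a carbonyl group. In this assay it made a step of a number 14.4 percentage points lower from compound 1 to compound 2 (beyond the scatter).

Compound 4, `CC(C)(C)OC(=O)/C(C#N)=C/c1ccoc1`, has not yet been measured. It stands to compound 3 as compound 2 stands to compound 1: the change is tert-butyl in place of ethyl on an oxygen next to a carbonyl group, the same change at the same place. On that single prior step it is expected that compound 4 will fall short of compound 3 in this assay by a step of about a number 13.9 percentage points lower from compound 3 to compound 4 (beyond the scatter), resting on the fact that compound 2 fell short of compound 1 by a number 14.4 percentage points lower from compound 1 to compound 2 (beyond the scatter). Going by the values given here, only one prior example of this change exists, and the two cores are not compared in detail, so the expectation carries a wide band. Compound 4 is estimated to give 42% in this assay, with a plausible range from 30% to 55%.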

Compound 4, a percentage reported as inhibition, in the whole organism at one dose (the size of the read-out at that dose, not a potency): 81.8%
The estimate for compound 4 lay 39.8 percentage points below the measured number; the whole stated range lies below it.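

In this assay, tert-butyl in place of ethyl on an oxygen next to a carbonyl group gave a number 25.9 percentage points higher from compound 3 to compound 4 (beyond the scatter), so on the core of compound 3 the change went the opposite way to its earlier step on the core of compound 1. Taken together, the two pairs show that neither the size nor the direction of this step carried from one core to the other, and that the outcome of the change depends on the core that bears it: the same change on two cores in this assay, a number 14.4 percentage points lower (beyond the scatter) from compound 1 to compound 2 and a number 25.9 percentage points higher (beyond the scatter) from compound 3 to compound 4, 40.3 percentage points apart, beyond the scatter of two such steps. For the compounds shown here, this does not show which feature of the two cores sets the difference, and with only two pairs it gives no rule for predicting the step on any further core; the read-out is also a percentage at one dose and not a potency.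

The compounds shown have only ethyl or tert-butyl on that oxygen, which leaves open what a longer chain there would do, or an amide or a carboxylic acid in place of the ester. Going by these compounds, it also remains open how the same change from ethyl to tert-butyl would behave on a core carrying an amine.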